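A few compounds are considered here, and "the series" means these few. Any claim that something is new, unique, unknown or untested is made for them only; others in the source may bear on it.

Measured so far in a functional assay on NCI-H322M cells (Homo sapiens) for cytotoxicity, read by sulforhodamine B assay, with a stated time of 48 h, tested at 1 uM; a lower number here means a stronger effect, a higher number a weaker effect of the compound at the concentration tested:
- compound 1, `COc1cc(-c2cc(/C=C/C(=O)c3ccc(N)cc3)[nH]n2)cc(OC)c1OC`, gives 94%
- compound 2, `COc1cc(-c2cc(/C=C/C(=O)c3ccc(Cl)c(Cl)c3)[nH]n2)cc(OC)c1OC`, gives 94%

Compound 2 thus stands level with compound 1 at the digits shown, both near the top of the scale, which means only a weak effect at the concentration tested. Among the measured compounds shown here, the one step between them, no change at the digits printed from compound 1 to compound 2 (within the scatter), came with 3,4-dichlorophenyl in place of 4-aminophenyl on a carbonyl carbon and stayed within the scatter.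

Compound 3, `COc1ccc(C(=O)/C=C/c2cc(-c3cc(OC)c(OC)c(OC)c3)n[nH]2)cc1OC`, keeps the shared core and changes the same place: 3,4-dimethoxyphenyl in place of 3,4-dichlorophenyl on a carbonyl carbon. For the measured compounds named here, the only measured step that bears on this change is the one from compound 1 to compound 2, an exchange of the aryl group on the same carbonyl carbon, and it moved nothing beyond the scatter. On that single precedent the step of a number 2 percentage points lower from compound 2 to compound 3 (within the scatter) is expected to stay within the scatter as well. Compound 3 is therefore estimated at 92%, with a range from 76% to 104%.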

Compound 3, a percentage reported as activity, at one concentration (the size of the read-out at that concentration, not a potency): 83%
Compound 3: middle estimate off by 9 percentage points, on the high side, within the range that was stated.
By their numbers in this assay, from the lowest: compound 3; then compounds 1 and 2 (each within the scatter of the next).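

In this assay, the exchange of 3,4-dichlorophenyl for 3,4-dimethoxyphenyl on a carbonyl carbon gives a number 11 percentage points lower from compound 2 to compound 3 (beyond the scatter) and the exchange of 4-aminophenyl for the same group gives a number 11 percentage points lower from compound 1 to compound 3 (beyond the scatter) as its counterpart. The position is therefore not silent, as the first pair alone might have suggested: the group on this carbonyl carbon can move the read-out beyond the scatter, though the shift is modest and the effect at this concentration remains weak. Nothing available explains why 3,4-dimethoxyphenyl differs from the other two groups.

The compounds shown leave open whether the shift belongs to the methoxy groups as such, and whether hydroxyl groups or longer ethoxy chains in their place would carry it further. Also open, going by these compounds, is whether any group at this position can produce a strong effect at this concentration.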